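Alkoxy chain length and cytotoxicity in a purine series

The source may report more compounds than this note shows. Statements on the series, on what has been measured and on what is new or still open speak of the compounds shown alone.

Compound 1 `C=CCOc1nc(N)nc2c1ncn2/C=C1/CC1(CO)CO`: > 300000 nM in an ADME assay on HFF cells (Homo sapiens) for cytotoxicity, with a stated time of 8 days (on this read-out lower numbers stand for higher toxicity in this test and higher numbers for lower toxicity in this test), a limit of the assay rather than a number.
Compound 2 `CCCCCCCCOc1nc(N)nc2c1ncn2/C=C1/CC1(CO)CO`: > 300000 nM, again a limit.
Compound 3 `Nc1nc(OCc2ccccc2)c2ncn(/C=C3/CC3(CO)CO)c2n1`: > 300000 nM, also a limit.

All three measured compounds share one core and differ only in the group on the saturated chain carbon bound to an oxygen on the aromatic ring. Compound 1 stands at the limit, and so do its two neighbours; the limit of > 300000 nM in this assay, at which 3 of the 3 values shown sit, is the whole of what the numbers show. The steps a step that the two limits leave unreadable from compound 1 to compound 2, a step that the two limits leave unreadable from compound 1 to compound 3 and a step that the two limits leave unreadable from compound 2 to compound 3 are therefore unreadable in size: replacing vinyl by heptyl or by phenyl, or heptyl by phenyl, produced no value inside the range of this assay.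

Compound 4 `CCCCCOc1nc(N)nc2c1ncn2/C=C1/CC1(CO)CO` differs from compound 1 by butyl in place of vinyl on a saturated chain carbon bound to an oxygen on an aromatic ring. The step from vinyl to butyl sits between the two unreadable steps from compound 1, both of which ended at the same limit. Within the data shown here, no measured step gives a direction, so the expectation for compound 4 is that it too remains at or beyond the limit, with a number no higher from compound 1 to compound 4 (the limit leaves the size open) expected to be no step at all. Compound 4 is estimated at 300000 nM, within 100000 nM to 1000000 nM.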

Compound 4, half-maximal cytotoxic concentration: 259000 nM
The estimate for compound 4 lay 1.2-fold (0.06 log units) above the measured number, within the range that was stated.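

Compound 4, with butyl in place of vinyl, gives the only number inside the range of this assay among the compounds shown, so a change at this position can yield a readable value; the other three stay at the limit: the limit of > 300000 nM in this assay, at which 3 of the 4 values shown sit. The comparisons with those three are an at least 1.1-fold lower number from compound 1 to compound 4 (0.06 log units; that floor lies within the scatter), an at least 1.1-fold lower number from compound 3 to compound 4 (0.06 log units; that floor lies within the scatter) and an at least 1.1-fold lower number from compound 2 to compound 4 (0.06 log units; that floor lies within the scatter), and each is only a floor set by a limit, so none establishes a difference in cytotoxicity beyond the usual scatter. Chain length therefore shows no order: the pentyloxy compound is the only readable one, and the compounds carrying vinyl and heptyl on the same carbon offer no number to rank it against.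

Going by these compounds, how far the values of compound 1, compound 2 and compound 3 lie past their limits remains open, and with it the true size of all three steps. Also open, on these data alone, is whether an amine or a carboxylic acid in place of butyl at this position would bring the number down by more than the usual scatter.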